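The source may hold more compounds than are shown below. What is called first, only, known or untested is meant among the compounds shown, and "the series" means these compounds.

In a functional assay on MDA-MB-231 cells (Homo sapiens) for cytotoxicity, read by MTT assay, with a stated time of 48 h (a higher number here means a weaker inhibitor, a lower number a stronger inhibitor), compound 1 `COc1ccc(C2=NOC(COc3ccc(-c4nnnn4-c4cc(OC)c(OC)c(OC)c4)cc3N)C2)cc1OC` gives 3570 nM. Sharing the core of compound 1 but much smaller as a molecule, compound 2 `COc1ccc(-c2nnnn2-c2cc(OC)c(OC)c(OC)c2)cc1N` gives 3170 nM. Among the measured compounds shown here, these two numbers lie within the usual scatter of each other, so compound 1 stands level with the only other compound measured so far. For the measured compounds named here, no measured pair differs in just one place.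

Compound 3 `COc1ccc(C2=NOC(COc3ccc(-c4nnnn4-c4cc(OC)c(OC)c(OC)c4)cc3N)C2)cc1[N+](=O)[O-]` differs from compound 1 by a single swap: nitro in place of methoxy on an aromatic carbon, ortho to a methoxy group and meta to a large group (nitro in place of methoxy on an aromatic carbon). No measurement tests this swap directly, so the data cannot settle the direction. Still, compound 1 at 3570 nM and compound 2 at 3170 nM differ widely in size yet give values within the scatter, so only a modest effect is expected here. The expected step, a 1.3-fold lower number from compound 1 to compound 3 (0.11 log units; within the scatter), is no larger than the scatter, with a slight lean towards a stronger inhibitor. For compound 3 the estimated value is 2800 nM, with an expected range of 1000 nM to 7500 nM.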

Compound 3, half-maximal inhibitory concentration: 3560 nM
For compound 3 the middle estimate is 1.3-fold (0.10 log units) below the measured one; measured number inside the range.
By their numbers in this assay, from the lowest: compounds 2, 3 and 1 (each within the scatter of the next).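

In this assay, among the compounds shown here, the swap of methoxy for nitro, which turns 3,4-dimethoxyphenyl into 4-methoxy-3-nitrophenyl, gives a 1.0-fold lower number from compound 1 to compound 3 (0.00 log units; within the scatter) and is the first direct reading at this position. At this aromatic carbon, ortho to a methoxy group and meta to a large group, the two groups therefore stand level in this assay, even though they differ in their atoms and in their count of hydrogen-bond acceptors. Nothing available here explains why the two groups read alike.

The compounds shown compare only these two groups at this carbon, so it remains open whether an amine, a hydroxyl or a longer alkoxy chain there would also stand level or would move the number beyond the scatter. From the compounds shown here alone, it also remains open whether the methoxy group on the other side of this swap, the one kept in 4-methoxy-3-nitrophenyl, can be replaced in the same way.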